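This account rests on a few compounds, and the source may have more. Where it says the series, first, only, none or still open, it means among the compounds named here.

- compound 1 `CC(=O)Nc1ccc(S(=O)(=O)N2C/C(=C\c3ccccc3F)C(=O)/C(=C/c3ccccc3F)C2)cc1`: 5500 nM
- compound 2 `N#Cc1ccc(/C=C2\CN(S(=O)(=O)c3ccc(F)cc3)C/C(=C\c3ccccc3F)C2=O)cc1`: 20100 nM
- compound 3 `CC(=O)Nc1ccc(S(=O)(=O)N2C/C(=C\c3cccc([N+](=O)[O-])c3)C(=O)/C(=C/c3ccccc3F)C2)cc1`: 7850 nM

In a functional assay on QGY-7703 cells (Homo sapiens) for cytotoxicity, read by MTT assay, with a stated time of 24 h (on this read-out lower numbers stand for stronger inhibition and higher numbers for weaker inhibition), compound 3 gives 7850 nM, the second highest of the three numbers. That value lies within the scatter of compound 1, while compound 2 reads higher, beyond the scatter.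

Compound 4 `CC(=O)Nc1ccc(S(=O)(=O)N2C/C(=C\c3ccc(C#N)cc3)C(=O)/C(=C/c3ccccc3F)C2)cc1` carries 4-cyanophenyl in place of 3-nitrophenyl on a double-bonded chain carbon bound to a double-bonded ring carbon.

For the measured compounds named here, only one measured step changes a group at this place. That step, a 1.4-fold higher number from compound 1 to compound 3 (0.15 log units; within the scatter), is small. Compound 2, at 20100 nM, also carries 4-cyanophenyl, but it differs from compound 4 elsewhere, so its number cannot be tied to that group alone. It does give some reason to lean towards a slightly higher number.

No change beyond the scatter is therefore expected in this assay. The expected step is a 1.1-fold higher number from compound 3 to compound 4 (0.06 log units; within the scatter). For compound 4, the estimated value is 9000 nM, with an expected range of 4500 nM to 18000 nM.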

Compound 4, half-maximal inhibitory concentration: 2050 nM
Compound 4: the middle estimate sits 4.4-fold (0.64 log units) above what was measured; measured number below the stated range.
By their numbers in this assay, from the lowest: compound 4; then compounds 1 and 3 (each within the scatter of the next); then compound 2.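

In this assay, for the compounds shown here, the group at this place does matter: the one earlier step here stayed within the scatter, whereas 4-cyanophenyl in place of 3-nitrophenyl gives a 3.8-fold lower number from compound 3 to compound 4 (0.58 log units; beyond the scatter) and 4-cyanophenyl in place of 2-fluorophenyl gives a 2.7-fold lower number from compound 1 to compound 4 (0.43 log units; beyond the scatter) in the same direction. 4-Cyanophenyl does not settle the number alone, since acetamido in place of fluoro on an aromatic carbon, with 4-cyanophenyl present on both sides of the step, gives a 9.8-fold lower number from compound 2 to compound 4 (0.99 log units; beyond the scatter) as well. Nothing at hand explains why these numbers differ.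

The step from 3-nitrophenyl changes both the group and where it sits on the ring, so the compounds shown cannot separate the two, and a 4-nitrophenyl or 3-cyanophenyl compound would bear on that. From the compounds shown here alone, it also remains open whether a phenyl ring carrying an amine or a carboxylic acid at this place would follow the same direction.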